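Replacing a benzylamino arm with an oxopiperidinyl ring

The source may report more compounds than this note shows. Statements on the series, on what has been measured and on what is new or still open speak of the compounds shown alone.

The account concerns two measured compounds and one awaiting measurement, all sharing a common core. Compound 1 `CC(C(=O)NCc1ccc(C(F)(F)F)nc1NCc1ccc(Cl)cc1)c1ccc(NS(C)(=O)=O)c(F)c1` gives the highest number of the two measured in a functional assay on CHO-K1 cells for antagonist activity at transient receptor potential cation channel subfamily V member 1 (Homo sapiens), read by FLIPR (a lower number here means a stronger inhibitor, a higher number a weaker inhibitor), where compound 1 gives 65.7 nM. Within the data shown here, the only comparison available is compound 2 `CC(C(=O)NCc1ccc(C(F)(F)F)nc1N1CCC(Cc2cc(F)cc(F)c2)CC1)c1ccc(NS(C)(=O)=O)c(F)c1`, which in this assay gives 0.4 nM; the gap between compound 1 and compound 2 lies well beyond the usual scatter, with compound 2 the stronger inhibitor.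

Compound 3 `CC(C(=O)NCc1ccc(C(F)(F)F)nc1N1CCC(=O)CC1)c1ccc(NS(C)(=O)=O)c(F)c1` has not yet been measured. It differs from compound 1 in one place: 4-oxopiperidin-1-yl in place of (4-chlorobenzyl)amino on an aromatic carbon. Among the measured compounds shown here, no step between two measured compounds matches this exchange, so the expectation rests on compound 1 and compound 2 alone. The group entering compound 3 is smaller than the one leaving and carries no aromatic ring, whereas compound 2 owes its low number of 0.4 nM to a piperidinyl ring bearing a further aromatic group. The step of a 7.6-fold higher number from compound 1 to compound 3 (0.88 log units; beyond the scatter) is therefore expected to go toward a weaker inhibitor, beyond the scatter. Compound 3 is estimated to give 500 nM in this assay, within a range from 80 nM to 4000 nM.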

Compound 3, inhibition constant: 91 nM
Compound 3: middle estimate off by 5.5-fold (0.74 log units), on the high side; the range from low to high includes it.
By their numbers in this assay, from the lowest: compound 2; then compounds 1 and 3 (each within the scatter of the next).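

In this assay, the exchange of (4-chlorobenzyl)amino for 4-oxopiperidin-1-yl on this aromatic carbon, next to the ring nitrogen, gives a 1.4-fold higher number from compound 1 to compound 3 (0.14 log units; within the scatter), so the six-membered aromatic ring and the hydrogen-bond donor of the leaving group can both be absent here without a change beyond the scatter. A piperidine ring on this carbon is also not enough in itself for a very low number: compound 3 carries one and gives 91 nM, while compound 2, whose piperidine ring bears a difluorobenzyl group, gives 0.4 nM. Nothing available explains why the two groups exchanged here give numbers within the scatter of each other.

The compounds shown leave open whether the carbonyl of 4-oxopiperidin-1-yl matters at all, a question that plain piperidin-1-yl or 4-hydroxypiperidin-1-yl on the same carbon would address. They also leave open how much of the low number of compound 2 depends on its two fluorine atoms, which 4-benzylpiperidin-1-yl without fluorine would help to settle.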